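Trimming the Amide Arm of Compound 2

A few compounds are considered here, and "the series" means these few. Any claim that something is new, unique, unknown or untested is made for them only; others in the source may bear on it.

Compound 2 `CCOC(=O)N1CCC(NS(=O)(=O)c2ccc(C(=O)Nc3ccccc3C)c3ccccc23)CC1` gives 5.21 nM in an assay on L1.2 cells for binding affinity to C-C chemokine receptor type 8 (Homo sapiens) (a lower number here means a stronger inhibitor, a higher number a weaker inhibitor), the lowest of the two numbers recorded there. Compound 3 `Cc1ccccc1C(=O)Nc1ccc(S(=O)(=O)NC2CCN(C(=O)NC(C)C)CC2)c2ccccc12`, which carries the same amide arm but a different group on the far side of the sulfonamide, gives 77.7 nM in this assay, a gap that lies beyond the scatter. Compound 1 `CN1CCN(S(=O)(=O)c2ccc(NC(=O)c3ccccc3)c3ccccc23)CC1` reaches only a limit of this assay, > 30000 nM. the limit of > 30000 nM in this assay, at which 1 of the 3 values shown sits, shows that one of the three values sits at that limit. Compound 1 differs from compound 2 in more than one place, so its value alone does not point to any single change.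

Compound 4 `CCOC(=O)N1CCC(NS(=O)(=O)c2ccc(N)c3ccccc23)CC1` is the member not yet measured: amino in place of (2-methylphenyl)carbamoyl on an aromatic carbon. The amide arm shared by compound 2 and compound 3, the two compounds with real numbers, is absent from compound 4. Among the compounds with values here, no step between two measured compounds removes this arm, so the size of the change cannot be read from the data. A large loss of binding is expected, toward a higher number in this assay, with a fair chance that only a limit is reported. Compound 4 is estimated at 5000 nM, within 500 nM to 30000 nM. The expected step from compound 2 to compound 4 is a 960-fold higher number from compound 2 to compound 4 (2.98 log units; beyond the scatter).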

Compound 4, inhibition constant: > 5000 nM
Compound 4: only a limit was reported (the forecaster's own chance of this, stated with the estimate: 30%); the middle value lies on the limit itself.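

Within the data shown here, this is the first step that changes the amide arm alone: with the rest of the molecule kept, amino in place of (2-methylphenyl)carbamoyl on the aromatic carbon gives an at least 950-fold higher number from compound 2 to compound 4 (2.98 log units; beyond the scatter) in this assay. The earlier compounds shown here differed in more than one place or on the far side of the sulfonamide, so they could not show that binding depends so strongly on what sits at this position, and that amino cannot stand in for the arm. The reading for compound 4 is a limit and not a number, so the step sets a floor on the loss and does not give its full size: the limit of > 5000 nM in this assay, at which 1 of the 4 values shown sits.

The compounds shown leave open which part of the arm carries the effect, whether the carbonyl, the amide hydrogen, the aromatic ring or its methyl group. A short acetamide or a plain phenylcarbamoyl without the methyl group at this aromatic carbon would begin to separate these parts, and a number rather than a limit would be needed to size each one.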